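Urea-type analogue of compound 1 in melanoma cell killing

The compounds below may be only part of what the source reports. "The series", "measured", "known", "first", "only" and "open" are said of these compounds alone.

Compound 1 `COc1cc(-c2nn(-c3cccc(NC(=O)c4cccc(C(F)(F)F)c4)c3)cc2-c2ccncc2)ccc1Cl` is the reference point of this short series. In a functional assay on SK-MEL-28 cells (Homo sapiens) for inhibition, read by sulforhodamine B assay, with a stated time of 48 h (a higher number here means that more compound is tolerated, a lower number that less compound is tolerated), compound 1 gives only a limit of the assay, > 50000 nM. Compound 2 `COc1cc(-c2nn(-c3cccc(NC(=O)Nc4ccc(Cl)c(Cl)c4)c3)cc2-c2ccncc2)ccc1Cl` in this assay likewise gives only a limit, > 50000 nM. Compound 3 `O=C(Nc1cccc(-n2cc(-c3ccncc3)c(-c3ccc(Cl)c(O)c3)n2)c1)Nc1ccc(Cl)c(Cl)c1` in this assay also reaches only a limit, > 32500 nM. The step that the two limits leave unreadable from compound 1 to compound 2 and the step that the two limits leave unreadable from compound 2 to compound 3 are consequently both without a readable size; the evidence behind them is the limit of > 50000 nM in this assay, at which 2 of the 3 values shown sit, and (the limit of > 32500 nM in this assay, at which 1 of the 3 values shown sits). Compound 4 `COc1cc(-c2nn(-c3cccc(NC(=O)Nc4cccc(C(F)(F)F)c4)c3)cc2-c2ccncc2)ccc1Cl` differs from compound 1 by (3-(trifluoromethyl)phenyl)amino in place of 3-(trifluoromethyl)phenyl on a carbonyl carbon. Among the compounds with values here, this change resembles the step to compound 2, which itself gave no readable size, so no measured step with a size bears on it, and no direction can be drawn from the measured compounds. Compound 4 in this assay is expected to give 50000 nM, within 20000 nM to 100000 nM, most likely reported as a limit again. The expected step of a number no higher from compound 1 to compound 4 (the limit leaves the size open) is thus estimated as none beyond the scatter.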

Compound 4, concentration lethal to 50% of the cells: 21100 nM
Compound 4: middle estimate off by 2.4-fold (0.37 log units), on the high side, and the stated range covers the measured number.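

With the 3-(trifluoromethyl)phenyl kept, placing an amino link on the carbonyl carbon gives the first readable move in this assay, an at least 2.3-fold lower number from compound 1 to compound 4 (0.37 log units; beyond the scatter). Compound 2 carries the same link, yet 3-(trifluoromethyl)phenyl in place of 3,4-dichlorophenyl on the amide-type nitrogen gives an at least 2.3-fold lower number from compound 2 to compound 4 (0.37 log units; beyond the scatter), so the link alone does not set the value and the group on that nitrogen counts as well. Both steps give only a minimum size, and they rest on: the limit of > 50000 nM in this assay, at which 2 of the 4 values shown sit.

From the compounds shown here alone, the full size of either step stays open, as does whether hydrogen in place of methyl on the oxygen changes the value of compound 4. Also open, going by these compounds, is whether an amine or a carboxylic acid in place of the trifluoromethyl would keep this step.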